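Amide Cap Swap in a Chemokine Receptor Series

The compounds below may be only part of what the source reports. "The series", "measured", "known", "first", "only" and "open" are said of these compounds alone.

Three compounds share a common core and differ only in the group attached to the amino acid nitrogen. Compound 1 `CC(C)C(NS(=O)(=O)Cc1ccccc1)C(=O)N1CCC(c2ccc(Cl)cc2)CC1` carries a sulfonamide and in an assay on THP-1 cells for displacement of a labelled ligand from C-C chemokine receptor type 1 (Homo sapiens) (a higher number here means a weaker inhibitor, a lower number a stronger inhibitor), compound 1 gives 303 nM. Compound 3 `CC(C)C(NC(=O)c1ccc2ccccc2c1)C(=O)N1CCC(c2ccc(Cl)cc2)CC1` carries a naphthalene amide, and in this assay compound 3 gives 80 nM. Compound 2 `CC(C)[C@@H](NC(=O)c1nc2ccccc2s1)C(=O)N1CCC(c2ccc(Cl)cc2)CC1` has the lowest number of the three: in this assay compound 2 gives 18 nM, which lies beyond the scatter from both compound 3 and compound 1.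

Compound 4 `Cc1ccc(CCC(=O)N[C@@H](C(=O)N2CCC(c3ccc(Cl)cc3)CC2)C(C)C)cc1` is not yet measured. It differs from compound 2 in one place: 2-(4-methylphenyl)ethyl in place of 1,3-benzothiazol-2-yl on a carbonyl carbon. Among the compounds with values here, no measured pair shows this particular change, so the size of the step can only be judged from the spread among the three measured compounds. Given that the two measured amides, compound 2 at 18 nM and compound 3 at 80 nM, already differ beyond the scatter, the change to the entering group is expected to move the number upward, by about a 6.7-fold higher number from compound 2 to compound 4 (0.82 log units; beyond the scatter). Compound 4 is therefore expected to give roughly 120 nM in this assay, within a range from 35 nM to 400 nM.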

Compound 4, half-maximal inhibitory concentration: 105 nM
For compound 4 the middle estimate is 1.1-fold (0.06 log units) above the measured one; low and high end bracket the measured number.
By their numbers in this assay, from the lowest: compound 2; then compounds 3 and 4 (each within the scatter of the next); then compound 1.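

In this assay, within the data shown here, putting 2-(4-methylphenyl)ethyl in place of 1,3-benzothiazol-2-yl on a carbonyl carbon gives a 5.8-fold higher number from compound 2 to compound 4 (0.77 log units; beyond the scatter) and this is the first step that can be read at a single place. The two groups have the same count of heavy atoms, so this position responds to more than that count: the nitrogen, the sulfur and the five-membered aromatic ring leave, and the group that enters has a carbon chain, one six-membered aromatic ring and no hydrogen-bond acceptors. No measurement shown here explains the rise in the number.

All of these differences change together in the one step, so the compounds shown do not tell which of them carries it. On these data alone, it remains open whether a 1,3-benzoxazol-2-yl group, with oxygen in place of sulfur, or an unsubstituted 2-phenylethyl group would stand closer to compound 2 or to compound 4, and what an amine on the ethyl chain would do to the number.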